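A few compounds are considered here, and "the series" means these few. Any claim that something is new, unique, unknown or untested is made for them only; others in the source may bear on it.

Series values in a functional assay on A549 cells (Homo sapiens) for cytotoxicity, read by MTT assay, with a stated time of 72 h; a higher number here means a weaker inhibitor, a lower number a stronger inhibitor:
- compound 1 `Cn1ccc2c(Oc3ccc(NC(=O)c4cc5cccnc5n(-c5ccccc5)c4=O)cc3F)ncnc21`: 63200 nM
- compound 2 `Cn1ccc2c(Oc3ccc(NC(=O)c4cc5cccnc5n(-c5ccc(Cl)cc5)c4=O)cc3F)ncnc21`: 55500 nM
- compound 3 `Cn1ccc2c(Oc3ccc(NC(=O)c4cc5cccnc5n(-c5ccc(Br)cc5)c4=O)cc3F)ncnc21`: 42200 nM

Compound 1 sits level with the other two, since its steps to both lie within the scatter and no order can be drawn among the three.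

Next is compound 4 `O=C(Nc1ccc(Oc2ncnc3[nH]ccc23)c(F)c1)c1cc2cccnc2n(-c2ccccc2)c1=O`, not yet measured in this assay. The change from compound 1 is hydrogen in place of methyl on an aromatic nitrogen.

The measured steps offer only indirect guidance. a 1.1-fold lower number from compound 1 to compound 2 (0.06 log units; within the scatter), a 1.5-fold lower number from compound 1 to compound 3 (0.18 log units; within the scatter) and a 1.3-fold lower number from compound 2 to compound 3 (0.12 log units; within the scatter) are all halogen changes on an aromatic carbon, and none touches this nitrogen. The series therefore gives no measured size or direction for this change. A moderate shift to a lower number is assumed as a tentative judgement, with a wide range that also covers no change beyond the scatter.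

The expected step is a 2.5-fold lower number from compound 1 to compound 4 (0.40 log units; beyond the scatter).

For compound 4 the estimated value is 25000 nM, with an expected range of 4000 nM to 80000 nM.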

Compound 4, half-maximal inhibitory concentration: 45500 nM
Compound 4: the middle estimate sits 1.8-fold (0.26 log units) below what was measured, within the range that was stated.
By their numbers in this assay, from the lowest: compounds 3, 4, 2 and 1 (each within the scatter of the next).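

In this assay, going by these compounds alone, hydrogen in place of methyl on the aromatic nitrogen of the five-membered ring gives a 1.4-fold lower number from compound 1 to compound 4 (0.14 log units; within the scatter), the first measured step at this position, since the earlier steps were all halogen changes on an aromatic carbon. Compound 4 therefore stands level with compound 1, and the methyl on this nitrogen can be exchanged for hydrogen without a step beyond the scatter in this series. No measurement available here explains the size of this step.

Open, on these data alone, is whether an ethyl group or a longer chain ending in an amine on this nitrogen would leave the number level with compound 1 as well. Also open, as far as these compounds go, is whether hydrogen on this nitrogen gives a similar step when combined with the chloro of compound 2 or the bromo of compound 3.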